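A phenyl in place of oxolan-3-yl

A few compounds are considered here, and "the series" means these few. Any claim that something is new, unique, unknown or untested is made for them only; others in the source may bear on it.

Measured so far in a functional assay on HT-29 cells (Homo sapiens) for inhibition, read by luminescence and CellTiter-Glo, with a stated time of 24 h; on this read-out higher numbers stand for an effect only at larger amounts of compound and lower numbers for an effect already at smaller amounts:
compound 1 `CN1C(=S)[C@@H](NC(=O)c2nc(Cc3ccccc3)n(C)n2)COc2ccccc21` gives 2.5 nM
compound 2 `CCCCCn1nc(C(=O)N[C@H]2COc3ccccc3N(C)C2=S)nc1Cc1ccccc1` gives 805 nM
compound 3 `CN1C(=S)[C@@H](NC(=O)c2nc(Cc3ccccc3)n(CC3CCOC3)n2)COc2ccccc21` gives 4420 nM

In this assay compound 3 has the highest number of the three, and both other compounds lie beyond the scatter from it. Compound 4 `CN1C(=S)[C@@H](NC(=O)c2nc(Cc3ccccc3)n(Cc3ccccc3)n2)COc2ccccc21` differs from compound 3 in one place (phenyl in place of oxolan-3-yl on a saturated chain carbon bound to an aromatic nitrogen), with phenyl in place of oxolan-3-yl on a saturated chain carbon bound to an aromatic nitrogen. For the measured compounds named here, three measured steps bear on this change. Both a 320-fold higher number from compound 1 to compound 2 (2.51 log units; beyond the scatter) and a 1800-fold higher number from compound 1 to compound 3 (3.25 log units; beyond the scatter) are large, so each of these two substituents goes with a far higher number than compound 1 shows. By contrast, a 5.5-fold higher number from compound 2 to compound 3 (0.74 log units; beyond the scatter) is only modest. Compound 4 is substituted at the same place, so it is expected to stay near compound 2 (805 nM) and well away from compound 1. Going by the values given here, no measured compound carries phenyl here, so the range stays wide. A modest move to a lower number is expected, the estimated step being a 4.4-fold lower number from compound 3 to compound 4 (0.65 log units; beyond the scatter) in this assay overall. The estimated value for compound 4 is 1000 nM, with an expected range from 150 nM to 5000 nM on repeated measurement.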

Compound 4, half-maximal effective concentration: 414 nM
Estimate against measurement, compound 4: 2.4-fold (0.38 log units) above, and the stated range covers the measured number.
By their numbers in this assay, from the lowest: compound 1; then compounds 4 and 2 (each within the scatter of the next); then compound 3.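

In this assay the step of an 11-fold lower number from compound 3 to compound 4 (1.03 log units; beyond the scatter) is large, so the group entering at this saturated chain carbon bound to an aromatic nitrogen does matter: the change from (oxolan-3-yl)methyl to benzyl is not neutral, even though both groups sit far from compound 1. The step of a 1.9-fold lower number from compound 2 to compound 4 (0.29 log units; within the scatter) lies within the scatter, so phenyl and butyl cannot be told apart here, while a 170-fold higher number from compound 1 to compound 4 (2.22 log units; beyond the scatter) shows that phenyl, like butyl and oxolan-3-yl, goes with a far higher number than hydrogen does. Nothing available explains why oxolan-3-yl stands apart from phenyl and butyl.

The compounds shown leave open how an ethyl or propyl chain would fall between hydrogen and butyl. They also leave open whether an amine or a carboxylic acid at this place would stay with compound 4 or come closer to compound 1.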